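Swapping the aryl group on the amino linker

The compounds below may be only part of what the source reports. "The series", "measured", "known", "first", "only" and "open" are said of these compounds alone.

Compound 2 `Cc1ccccc1Nc1ccc(C#N)cc1S(=O)(=O)NC(=O)NC(C)C` gives 10100 nM in a functional assay on HEK293 cells for antagonist activity at thromboxane A2 receptor (Homo sapiens), read by fluorescence and calcium flux (a lower number here means a stronger inhibitor, a higher number a weaker inhibitor), the highest of the two numbers measured, though its companion compound 1 `CC(C)NC(=O)NS(=O)(=O)c1cc(C#N)ccc1Oc1ccc(F)cc1` gives 9300 nM, which is within the scatter. Compound 3 `CC(C)NC(=O)NS(=O)(=O)c1cc(C#N)ccc1Nc1ccc(F)cc1` differs from compound 2 by 4-fluorophenyl in place of 2-methylphenyl on a nitrogen on an aromatic ring. Among the measured compounds shown here, the only measured step, a 1.1-fold higher number from compound 1 to compound 2 (0.04 log units; within the scatter), changes both the linker and the aryl group at once, so no step isolates this change. The expected step of a 1.1-fold lower number from compound 2 to compound 3 (0.03 log units; within the scatter) is therefore none beyond the scatter. Compound 3 is estimated at 9500 nM, with a range of 4000 nM to 22000 nM.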

Compound 3, half-maximal inhibitory concentration: 7830 nM
The estimate for compound 3 lay 1.2-fold (0.08 log units) above the measured number; measured number inside the range.
By their numbers in this assay, from the lowest: compounds 3, 1 and 2 (each within the scatter of the next).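

Putting 4-fluorophenyl in place of 2-methylphenyl on the nitrogen gives a 1.3-fold lower number from compound 2 to compound 3 (0.11 log units; within the scatter), so these two aryl groups cannot be told apart in this assay. With 4-fluorophenyl kept, the linker can now be judged on its own: (4-fluorophenyl)amino in place of 4-fluorophenoxy gives a 1.2-fold lower number from compound 1 to compound 3 (0.07 log units; within the scatter), again no real difference. Nothing measured here offers a reason for these results.

As far as these compounds go, it remains open whether any group at this position moves the number beyond the scatter. A pyridine ring, an aryl ring carrying a carboxylic acid, or a longer alkyl chain on the nitrogen would test this.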